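The compounds below may be only part of what the source reports. "The series", "measured", "known", "first", "only" and "open" are said of these compounds alone.

Measured compounds:
compound 1 `CC1=NC(C)=C([N+](=O)[O-])C(c2cccnc2)/C1=C(\O)OC1CCCC1`: 3280 nM
compound 2 `CO/C(O)=C1\C(C)=NC(C)=C([N+](=O)[O-])C1c1cccnc1`: 70000 nM
compound 3 `CC1=NC(C)=C([N+](=O)[O-])C(c2cccnc2)/C1=C(\O)OC(C)(C)C`: 14600 nM

In a functional assay (cardiac atrium) for agonist activity, with Cavia porcellus as the target (a lower number here means that less compound is needed, a higher number that more compound is needed for the effect), compound 1 gives 3280 nM, compound 2 gives 70000 nM and compound 3 gives 14600 nM. Compound 3 therefore stands second highest of the three numbers: the step of a 4.5-fold higher number from compound 1 to compound 3 (0.65 log units; beyond the scatter) places it above compound 1, while the step of a 4.8-fold lower number from compound 2 to compound 3 (0.68 log units; beyond the scatter) places it below compound 2. The largest step seen is a 21-fold higher number from compound 1 to compound 2 (1.33 log units; beyond the scatter).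

Compound 4 `COCCO/C(O)=C1\C(C)=NC(C)=C([N+](=O)[O-])C1c1cccnc1` has not yet been measured. It differs from compound 3 in one place: 2-methoxyethyl in place of tert-butyl on an oxygen on an unsaturated carbon. All three measured steps change the group on this same oxygen, and all lie beyond the scatter, from modest to large; among them the methyl group gave the highest number and the cyclopentyl group the lowest. For the measured compounds named here, the entering 2-methoxyethyl is a chain that carries a hydrogen-bond acceptor, and no measured compound shows how such a chain behaves here. Compound 4 is expected to stay close to compound 3, with at most a modest rise in this assay, so the expected step is a 1.4-fold higher number from compound 3 to compound 4 (0.14 log units; within the scatter). The estimate for compound 4 is 20000 nM, with a range from 5000 nM to 70000 nM.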

Compound 4, half-maximal effective concentration: 49400 nM
Beside the measured number, compound 4's estimate is 2.5-fold (0.39 log units) below it; measured number inside the range.
By their numbers in this assay, from the lowest: compound 1; then compound 3; then compounds 4 and 2 (each within the scatter of the next).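

In this assay, the 2-methoxyethyl chain does not match the tert-butyl group, although both carry the same number of heavy atoms, and the step is a 3.4-fold higher number from compound 3 to compound 4 (0.53 log units; beyond the scatter) on this oxygen. Lengthening the methyl group to this chain brings no readable shift, since a 1.4-fold lower number from compound 2 to compound 4 (0.15 log units; within the scatter) leaves the two compounds unseparated, while the gap to the cyclopentyl group stays wide at a 15-fold higher number from compound 1 to compound 4 (1.18 log units; beyond the scatter) in the same assay. Heavy-atom count alone therefore does not set the number at this position, and nothing available explains why the hydrogen-bond acceptor chain falls where it does.

The compounds shown leave open how a longer ether chain, a chain ending in an amine, or a cyclohexyl ring on this oxygen would compare with compound 1. They also leave open whether an ethyl or isopropyl group would fall nearer the methyl or the cyclopentyl end.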